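Swapping methyl for chloro on a thioether side arm

The compounds below may be only part of what the source reports. "The series", "measured", "known", "first", "only" and "open" are said of these compounds alone.

The compounds share one core, carrying a propargylamine and a benzylthio side arm whose aromatic ring varies. Compound 1 `C#CCNC1CCc2c(SCc3ccc(Cl)cc3Cl)cccc21` bears a dichlorophenyl ring, compound 2 `C#CCNC1CCc2c(SCc3ccc4ccccc4c3)cccc21` a naphthyl ring, and compound 3 `C#CCNC1CCc2c(SCc3cccc(C)c3)cccc21` a 3-methylphenyl ring. In an assay on isolated protein for inhibition of Amine oxidase [flavin-containing] B (Homo sapiens) (a higher number here means a weaker inhibitor, a lower number a stronger inhibitor), compound 1 gives 3760 nM and compound 2 gives 4950 nM. For compound 3 this assay reports only a limit, > 100000 nM, so its true potency is not pinned to a number; it sits at the weak end of everything shown, at the limit of > 100000 nM in this assay, at which 1 of the 3 values shown sits. Among the compounds with values here, compound 4 `C#CCNC1CCc2c(SCc3cccc(Cl)c3)cccc21` is the not yet measured partner of compound 3: the only change is chloro in place of methyl on an aromatic carbon. Within the data shown here, with no measured pair that isolates this exact change, the size of the step has to be guessed from the spread of the three known values. The two compounds with numbers, compound 1 and compound 2, both carry chlorine or a larger ring and both give measurable values in this assay, which hints that the step from compound 3 to compound 4 is expected to move toward stronger inhibition, estimated as an at least 3.3-fold lower number from compound 3 to compound 4 (0.52 log units; beyond the scatter). Compound 4 is therefore expected to reach about 30000 nM, within a range from 8000 nM to 120000 nM.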

Compound 4, half-maximal inhibitory concentration: 23300 nM
Beside the measured number, compound 4's estimate is 1.3-fold (0.11 log units) above it; the measured number falls inside the stated range.
By their numbers in this assay, from the lowest: compounds 1 and 2 (each within the scatter of the next); then compound 4. At a limit, above all of these: compound 3.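

In this assay, within the data shown here, one change can now be read on its own for the first time: an at least 4.2-fold lower number from compound 3 to compound 4 (0.63 log units; beyond the scatter). With the rest of the molecule identical, going from 3-methylphenyl to 3-chlorophenyl on the side arm turns a result that is only a limit into a measured number, so a single heavy atom at this place on the ring matters to this enzyme. The size of this step is only a minimum because one end of it is a limit rather than a number, the limit of compound 3: the limit of > 100000 nM in this assay, at which 1 of the 4 values shown sits.

As far as these compounds go, the true gap between methyl and chloro at this place therefore stays unknown, and this one pair cannot tell whether the same swap would have a similar effect at another place on the ring or on a different side arm. From the compounds shown here alone, it also remains open how other groups at this same place, such as a methoxy, a nitrile or an amine, would read in this assay.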